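Cytotoxicity notes: benzyl substitution in the tricyclic sulfone series

A few compounds are considered here, and "the series" means these few. Any claim that something is new, unique, unknown or untested is made for them only; others in the source may bear on it.

The series shares a fused sulfone core carrying a hydroxy-quinolinone bearing an N-benzyl group. Compound 1 `CS(=O)(=O)c1ccc2c(c1)S(=O)(=O)C=C(c1c(O)c3cc(F)ccc3n(Cc3ccc(F)cc3)c1=O)N2` and compound 2 `CS(=O)(=O)Nc1ccc2c(c1)S(=O)(=O)C=C(c1c(O)c3cc(F)ccc3n(Cc3ccccc3)c1=O)N2` have both been run in an ADME assay on 2209-23 cells (Homo sapiens) for cytotoxicity, read by WST assay; on this read-out higher numbers stand for lower toxicity in this test and lower numbers for higher toxicity in this test. In this assay compound 1 reaches only the limit of the assay and gives > 50000 nM, which is not a number. In the same assay compound 2 likewise sits at the limit and gives > 50000 nM. Compound 2 thus stands where all measured material stands: the limit of > 50000 nM in this assay, at which 2 of the 2 values shown sit. No comparison between two numbers is therefore available within the series.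

Compound 3 `Cc1cc(Cn2c(=O)c(C3=CS(=O)(=O)c4cc(NS(C)(=O)=O)ccc4N3)c(O)c3cc(F)ccc32)ccc1F` is not yet measured. It differs from compound 2 by 4-fluoro-3-methylphenyl in place of phenyl on a saturated chain carbon bound to an aromatic nitrogen. Going by the values given here, nothing measured here speaks to this change, so the only anchor is that every value so far lies at the limit.

Compound 3 is expected to remain in the same region, with the estimate 50000 nM and a range of 15000 nM to 150000 nM. The step from compound 2 to compound 3 is estimated as a number no higher from compound 2 to compound 3 (the limit leaves the size open), a step not beyond the usual scatter, and most likely the assay again reports only a limit for compound 3.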

Compound 3, half-maximal cytotoxic concentration: > 50000 nM
Compound 3 was reported as a limit (the forecaster's own chance of this, stated with the estimate: 80%); the middle value lies on the limit itself.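

In this assay compound 3 gives > 50000 nM, a limit and not a number. No step from compound 2 to compound 3 can be read, as both values are limits: the limit of > 50000 nM in this assay, at which 3 of the 3 values shown sit.

The compounds shown leave open whether 4-fluoro-3-methylphenyl in place of phenyl changes this read-out at all, and at what concentration any of them becomes toxic to these cells.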